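Peroxide acids and esters: inverting two ring stereocentres

The source may hold more compounds than are shown below. What is called first, only, known or untested is meant among the compounds shown, and "the series" means these compounds.

Measured so far in a functional assay on KM12 cells (Homo sapiens) for cytotoxicity, read by colony formation; on this read-out higher numbers stand for weaker inhibition of growth and lower numbers for stronger inhibition of growth:
compound 1 `C=C1CCCC(C)(C)C1CC[C@]1(C)CC[C@@H]([C@@H](C)C(=O)O)OO1` — > 5000 nM
compound 2 `C=C1CCCC(C)(C)C1CC[C@]1(C)CC[C@H]([C@@H](C)C(=O)OC)OO1` — 400 nM
compound 3 `C=C1CCCC(C)(C)C1(O)CC/C(C)=C/CC[C@]1(C)CC[C@H]([C@@H](C)C(=O)OC)OO1` — > 5000 nM

The value of compound 1 in this assay is a limit of the assay, not a number. The value of compound 3 is likewise a limit. Going by the values given here, compound 2 is the only member with a measured number. Compound 1 therefore stands at the limit of > 5000 nM in this assay, at which 2 of the 3 values shown sit.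

Compound 4 `C=C1CCCC(C)(C)C1CC[C@@]1(C)CC[C@H]([C@@H](C)C(=O)O)OO1` differs from compound 1 thus: the two compounds have the same atoms and bonds; at least one stereo element is drawn with a configuration in one of them and without one in the other: 2 of 4 stereo elements differ; a stereocentre at a saturated ring carbon is drawn R in compound 1 and S in compound 4; a stereocentre at a saturated ring carbon is drawn S in compound 1 and R in compound 4. Among the compounds with values here, no measured pair isolates such an inversion, so no step size is available. Compound 4 keeps the free carboxylic acid of compound 1, which sits at the limit, and the expected step that the limit leaves unreadable from compound 1 to compound 4 is none beyond the scatter. Compound 4 is estimated at 8000 nM, in a range from 2000 nM to 30000 nM.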

Compound 4, concentration for 50% growth inhibition: 4820 nM
For compound 4 the middle estimate is 1.7-fold (0.22 log units) above the measured one; the range from low to high includes it.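

In this assay compound 4 gives a true number, 4820 nM, so an acid of this series now has a measured value after inversion of the two ring stereocentres. The change reads only as a floor: an at least 1.0-fold lower number from compound 1 to compound 4 (0.01 log units; that floor lies within the scatter). Compound 1 remains a limit, so the full size of the change cannot be read: the limit of > 5000 nM in this assay, at which 2 of the 4 values shown sit.

From the compounds shown here alone, whether the same inversion would change the value of the methyl ester remains open. Going by these compounds, the effect of an amide in place of the carboxylic acid also remains open.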